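Swapping the terminal amine on the urea of compound 2

The source may report more compounds than this note shows. Statements on the series, on what has been measured and on what is new or still open speak of the compounds shown alone.

Compound 1 `COc1cc(NC(C)CCCNC(=O)NN)c2ncccc2c1` — 70%
Compound 2 `COc1cc(NC(C)CCCNC(=O)NNC(=O)NC(CO)(CO)CO)c2ncccc2c1` — 49%

Of the compounds shown here, two have been measured in a physicochemical assay for inhibition, read by spectrophotometry, tested at 100 uM; a lower number here means less inhibition, a higher number more inhibition at the concentration tested (going by the name of the read-out). Compound 1 gives 70% in this assay, and compound 2 gives 49%. Among the compounds with values here, compound 2 therefore stands at the lower of the two numbers, with compound 1 as its only neighbour; the step of a number 21 percentage points lower from compound 1 to compound 2 (beyond the scatter) is the single measured step, and it concerns the attachment of the whole (2-hydroxy-1,1-bis(hydroxymethyl)ethyl)carbamoyl group to the amine nitrogen.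

Compound 3 `COc1cc(NC(C)CCCNC(=O)NNC(=O)N(CCO)CCO)c2ncccc2c1` keeps that carbamoyl framework and differs from compound 2 only at its far end: bis(2-hydroxyethyl)amino in place of (2-hydroxy-1,1-bis(hydroxymethyl)ethyl)amino on a carbonyl carbon. Within the data shown here, no measured step reports on exchanging one amine for another on that carbonyl carbon, so the step from compound 1 to compound 2 bears on it only indirectly, by showing the size of change the carbamoyl end can bring. With nothing directly comparable, the expectation is for compound 3 a step of a number 1 percentage points higher from compound 2 to compound 3 (within the scatter) that stays within the scatter, in no firm direction. Compound 3 is thus estimated at 50%, with a range from 35% to 65% in this assay.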

Compound 3, a percentage reported as inhibition, at one concentration (the size of the read-out at that concentration, not a potency): 43%
Estimate against measurement, compound 3: 7 percentage points above, and the stated range covers the measured number.
By their numbers in this assay, from the lowest: compounds 3 and 2 (each within the scatter of the next); then compound 1.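

In this assay, exchanging the amine on the carbonyl carbon gives a number 6 percentage points lower from compound 2 to compound 3 (within the scatter), so (2-hydroxy-1,1-bis(hydroxymethyl)ethyl)amino and bis(2-hydroxyethyl)amino cannot be told apart at this position, even though the entering group has fewer heavy atoms, hydrogen-bond donors and hydrogen-bond acceptors. Placing bis(2-hydroxyethyl)carbamoyl in place of hydrogen on the amine nitrogen gives a number 27 percentage points lower from compound 1 to compound 3 (beyond the scatter), so the separation from compound 1 seen with the first carbamoyl group also appears with a second amine end, and neither of the two carbamoyl compounds goes against this. Nothing available explains either step.

The compounds shown all carry hydroxyl groups on the carbamoyl end, so it remains open whether the separation from compound 1 depends on those groups or comes with the added carbamoyl unit itself, a question that a plain dimethylamino or a morpholine end on the same carbonyl carbon would address. On these data alone, it is also open whether a carboxylic acid or a longer chain at this end would stay with compound 2 and compound 3 or move away from them, and each reading here is a single-concentration inhibition figure rather than a potency.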